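The compounds below may be only part of what the source reports. "The series", "measured", "known", "first", "only" and "open" are said of these compounds alone.

Measured compounds in a functional assay on MDA-MB-435 cells (Homo sapiens) for inhibition, read by sulforhodamine B assay, with a stated time of 48 h; a lower number here means a stronger inhibitor of growth, a higher number a weaker inhibitor of growth:
- compound 1 `Nc1cc(N)c2nc(-c3ccccc3)c(NCc3ccc(Cl)c(Cl)c3)nc2c1`: 7590 nM
- compound 2 `Nc1cc(N)c2nc(-c3ccccc3)c(Oc3ccc(F)cc3)nc2c1`: 32400 nM

Two compounds share the same core and differ in the group attached to it. Compound 1 gives the lower of the two numbers in this assay, and compound 2 sits a good deal higher, beyond the usual scatter, so compound 1 stands as the stronger growth inhibitor of the pair.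

Compound 3 `COc1ccc(CNc2nc3cc(N)cc(N)c3nc2-c2ccccc2)cc1OC` has not yet been tested. It keeps the benzylamine-type attachment of compound 1 but changes the ring at its end: 3,4-dimethoxyphenyl in place of 3,4-dichlorophenyl on a saturated chain carbon bound to a nitrogen on an aromatic ring. Among the compounds with values here, no measured pair shows this exact change, so the size of the step is uncertain. A modest weakening is expected rather than a large one. The step from compound 1 to compound 3 in this assay is estimated at a 1.6-fold higher number from compound 1 to compound 3 (0.20 log units; within the scatter). Compound 3 is therefore expected to give about 12000 nM, likely between 4000 nM and 40000 nM.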

Compound 3, concentration for total growth inhibition: 4070 nM
Estimate against measurement, compound 3: 2.9-fold (0.47 log units) above, within the range that was stated.
By their numbers in this assay, from the lowest: compounds 3 and 1 (each within the scatter of the next); then compound 2.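

In this assay, 3,4-dimethoxyphenyl in place of 3,4-dichlorophenyl on a saturated chain carbon bound to a nitrogen on an aromatic ring gives a 1.9-fold lower number from compound 1 to compound 3 (0.27 log units; within the scatter) and so does not separate the two compounds. Within the data shown here, this is the first direct comparison at this position, and it shows that the end ring can carry two chlorine atoms or two methoxy groups with no difference that can be read here. That holds even though the entering group counts 2 hydrogen-bond acceptors and the leaving group 0, and nothing available explains the result.

Going by these compounds, it remains open whether an unsubstituted phenyl ring, or a ring bearing an amine or a carboxylic acid, would also fall within the scatter of these two compounds. On these data alone, the effect of a longer chain between the nitrogen and the ring is also open.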